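A Benzyl in Place of an Acetyl

The compounds below may be only part of what the source reports. "The series", "measured", "known", "first", "only" and "open" are said of these compounds alone.

In a functional assay on KB 3-1 cells (Homo sapiens), with a stated time of 1 h (a lower number here means that less compound is needed, a higher number that more compound is needed for the effect), compound 1 (`CC(=O)Oc1cc2oc(-c3ccccc3)cc(=O)c2c(OC(C)=O)c1OC(C)=O`) gives 6800 nM and compound 2 (`COc1cc2oc(-c3ccccc3)cc(=O)c2c(OC)c1OC(C)=O`) gives 11500 nM and these two values lie within the usual scatter of each other. Compound 3 (`CC(=O)Oc1cc2oc(-c3ccccc3)cc(=O)c2c(OCc2ccccc2)c1OC(C)=O`) has not yet been measured. It keeps the core of compound 1 but carries benzyl in place of acetyl on an oxygen on an aromatic ring. Going by the values given here, no measured step shows this change, so the expectation rests on compound 1 at 6800 nM and no step beyond the scatter is foreseen in this assay here. From the compounds shown here alone, the expected step is a 1.2-fold higher number from compound 1 to compound 3 (0.07 log units; within the scatter) and its direction remains open. For compound 3 the estimate is 8000 nM within an expected range of 3000 nM to 20000 nM around it.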

Compound 3, half-maximal effective concentration: 3700 nM
Compound 3: middle estimate off by 2.2-fold (0.33 log units), on the high side; measured number inside the range.
By their numbers in this assay, from the lowest: compounds 3, 1 and 2 (each within the scatter of the next, the first and the last beyond it).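

In this assay, benzyl in place of acetyl on an oxygen on an aromatic ring gives a 1.8-fold lower number from compound 1 to compound 3 (0.26 log units; within the scatter) and thus no step beyond the scatter. This oxygen can therefore carry a six-membered aromatic ring in place of the acetyl while the number stays within the scatter of that of compound 1. Nothing available explains this result. From the compounds shown here alone, what remains open is whether an amine or a carboxylic acid on this oxygen would also stay within the scatter of compound 1. Going by these compounds, whether a longer chain would do so is equally open.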